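Shortening a Chain by One Carbon on a Shared Core

The compounds below may be only part of what the source reports. "The series", "measured", "known", "first", "only" and "open" are said of these compounds alone.

Measured compounds:
compound 1, `CCc1nc(Cl)ncc1C(=O)Nc1cc(C(F)(F)F)cc(C(F)(F)F)c1`: 400 nM
compound 2, `O=C(Nc1cc(C(F)(F)F)cc(C(F)(F)F)c1)c1ccc(Cl)cc1C(F)(F)F`: > 30000 nM, a limit of the assay

For the measured compounds named here, in an assay on Jurkat cells for activation of nuclear factor NF-kappa-B complex (Homo sapiens) (on this read-out higher numbers stand for weaker inhibition and lower numbers for stronger inhibition), compound 1 gives 400 nM, the only number among the measured compounds. For compound 2 the assay reports only a limit, > 30000 nM, which is the entry described by the limit of > 30000 nM in this assay, at which 1 of the 2 values shown sits. Going by the values given here, compound 2 carries a different core from compound 1, so no single-change step between measured compounds exists and nothing is known about how small changes on the core of compound 1 move the read-out.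

Compound 3, `Cc1nc(Cl)ncc1C(=O)Nc1cc(C(F)(F)F)cc(C(F)(F)F)c1`, differs from compound 1 by hydrogen in place of methyl on a saturated chain carbon bound to an aromatic carbon. Cut one bond further out, the same difference reads ethyl to methyl. A change this small is expected to give a step of a 1.5-fold higher number from compound 1 to compound 3 (0.18 log units; within the scatter), at most slightly beyond the usual scatter and, if anything, toward weaker inhibition. Compound 3 is therefore estimated at 600 nM, with a likely range from 200 nM to 2000 nM.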

Compound 3, half-maximal inhibitory concentration: 50 nM
For compound 3 the middle estimate is 12-fold (1.08 log units) above the measured one, and the stated range ends above it.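

In this assay, hydrogen in place of methyl on a saturated chain carbon bound to an aromatic carbon, which reads ethyl to methyl one bond further out, gives an 8.0-fold lower number from compound 1 to compound 3 (0.90 log units; beyond the scatter) on the shared core. This is the only single-change step among the compounds shown, and it reveals that the read-out at this position responds to the loss of one carbon, with the methyl compound showing the stronger inhibition. Nothing given here accounts for the size of this step.

A single step cannot tell whether the read-out follows chain length at this position, and a propyl chain or a cyclopropyl group there would test that. From the compounds shown here alone, how an amine or a carboxylic acid elsewhere on the shared core would move the read-out also stays open.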